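Swapping 4-fluorobenzyl for 1-phenylethyl at the amide nitrogen

The compounds below may be only part of what the source reports. "The series", "measured", "known", "first", "only" and "open" are said of these compounds alone.

Three compounds share one core and differ only in the group attached to the amide-type nitrogen. Going by the values given here, compound 1 `CN(Cc1ccccc1)C(=O)c1nc(Cc2ccccc2C(F)(F)F)n(C)c(=O)c1O` is the first. In an ADME assay on HepG2 cells (Homo sapiens) for cytotoxicity, in the presence of a further agent that is not named here (a lower number here means a stronger inhibitor, a higher number a weaker inhibitor), compound 1 gives only a limit, > 100000 nM. Compound 2 `Cn1c(Cc2ccccc2C(F)(F)F)nc(C(=O)NCc2ccccn2)c(O)c1=O` likewise gives only a limit in this assay, > 100000 nM. Compound 3 `Cn1c(Cc2ccccc2C(F)(F)F)nc(C(=O)NCc2ccc(F)cc2)c(O)c1=O` also gives only a limit there, > 100000 nM. Compound 3 thus stands at the limit without a number of its own, as the limit of > 100000 nM in this assay, at which 3 of the 3 values shown sit, records. Compound 4 `CC(NC(=O)c1nc(Cc2ccccc2C(F)(F)F)n(C)c(=O)c1O)c1ccccc1` differs from compound 3 by 1-phenylethyl in place of 4-fluorobenzyl on an amide-type nitrogen. The two steps that touch compound 3, a step that the two limits leave unreadable from compound 1 to compound 3 and a step that the two limits leave unreadable from compound 2 to compound 3, leave their size unreadable, so neither direction nor size can be drawn from them. Compound 4 is therefore expected to remain at the same limit, the expected step being a step that the limit leaves unreadable from compound 3 to compound 4 and the estimate 150000 nM between 50000 nM and 500000 nM.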

Compound 4, half-maximal inhibitory concentration: > 100000 nM
Compound 4: no number, only a limit; the forecaster's own chance of this, stated with the estimate: 85%; the middle value does not contradict the limit.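

Compound 4 also gives only a limit, so its steps from compound 1, compound 2 and compound 3 cannot be read in this assay. From the compounds shown here alone, whether any of these amide groups changes the half-maximal inhibitory concentration at all stays open.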